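This account rests on a few compounds, and the source may have more. Where it says the series, first, only, none or still open, it means among the compounds named here.

Compound 1 `Nc1cc(N)c2nc(-c3ccccc3)c(Oc3ccc(Cl)c(Cl)c3)nc2c1` in a functional assay on HCT-15 cells (Homo sapiens) for inhibition, read by sulforhodamine B assay, with a stated time of 48 h (a lower number here means that less compound is tolerated, a higher number that more compound is tolerated), gives < 100000 nM.
Compound 2 `CCOC(=O)[C@H](CCC(=O)O)NC(=O)c1ccc(CNc2nc3cc(N)cc(N)c3nc2-c2ccccc2)cc1` in this assay gives < 100000 nM.
Compound 3 `COc1cc(CNc2nc3cc(N)cc(N)c3nc2-c2ccccc2)cc(OC)c1OC` in this assay gives < 50200 nM.

Each of these three results is a limit of the assay and not a number. Compound 1 sits at the limit of < 100000 nM in this assay, at which 2 of the 3 values shown sit. Compound 3 sits at the limit of < 50200 nM in this assay, at which 1 of the 3 values shown sits. Compound 1 therefore stands nowhere in particular among the values shown: all three are limits, and none can be ordered against another.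

The next compound, compound 4 `Nc1cc(N)c2nc(-c3ccccc3)c(NCc3ccc(F)cc3)nc2c1`, differs from compound 1 in one place: (4-fluorobenzyl)amino in place of 3,4-dichlorophenoxy on an aromatic carbon. Going by the values given here, no step between two measured compounds is available, so the size of the change that this exchange brings in this assay cannot be read off anything measured here. With all three measured compounds at limits, the expectation for compound 4 is that it too will most likely be reported as a limit, with no step beyond the scatter that can be claimed in either direction.

The estimate for compound 4 in this assay is 50000 nM, within a range from 10000 nM to 100000 nM. The expected step that the limit leaves unreadable from compound 1 to compound 4 rests on nothing more than the limits shown.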

Compound 4, concentration lethal to 50% of the cells: < 100000 nM
Compound 4: no number, only a limit (the forecaster's own chance of this, stated with the estimate: 60%); the middle value is on the limit's open side.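

In this assay compound 4 gives < 100000 nM, which is a limit of the assay and not a number. Going by these compounds alone, compound 1 gives < 100000 nM, also a limit, so no step between compound 1 and compound 4 can be read. The compounds shown leave open how (4-fluorobenzyl)amino in place of 3,4-dichlorophenoxy on an aromatic carbon affects this read-out, in size or direction.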